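Halogen swap on a shared core: fluoro to chloro

The source may report more compounds than this note shows. Statements on the series, on what has been measured and on what is new or still open speak of the compounds shown alone.

Measured compounds:
- Compound 1, `CNc1ccc(Sc2ccc([N+](=O)[O-])cc2)c(C(=O)Nc2ccccc2OC)c1`: 302000 nM
- Compound 2, `COc1ccccc1NC(=O)c1cc(F)ccc1Sc1ccc([N+](=O)[O-])cc1`: 502000 nM

In an ADME assay on H9 cells (Homo sapiens) for cytotoxicity, read by MTT assay, with a stated time of 7 days (on this read-out higher numbers stand for lower toxicity in this test and lower numbers for higher toxicity in this test), compound 2 gives the highest of the two numbers, but the gap between the two is only a 1.7-fold higher number from compound 1 to compound 2 (0.22 log units; within the scatter), so the two values cannot be told apart. Compound 3, `COc1ccccc1NC(=O)c1cc(Cl)ccc1Sc1ccc([N+](=O)[O-])cc1`, is not yet measured. It differs from compound 2 by a single change: chloro in place of fluoro on an aromatic carbon. For the measured compounds named here, no measured step involves a chloro group, so nothing among the measured compounds speaks directly to this change. The only step shown, a 1.7-fold higher number from compound 1 to compound 2 (0.22 log units; within the scatter), is a larger exchange that still stayed within the scatter. For compound 3 the expected step in this assay is therefore a 1.1-fold lower number from compound 2 to compound 3 (0.05 log units; within the scatter), with no clear direction beyond the scatter. Compound 3 is estimated at 450000 nM, within a range from 200000 nM to 1000000 nM.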

Compound 3, half-maximal cytotoxic concentration: 483000 nM
Compound 3: the middle estimate sits 1.1-fold (0.03 log units) below what was measured; the measured number falls inside the stated range.
By their numbers in this assay, from the lowest: compounds 1, 3 and 2 (each within the scatter of the next).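

Chloro in place of fluoro on this aromatic carbon gives a 1.0-fold lower number from compound 2 to compound 3 (0.02 log units; within the scatter) in this assay, so these two halogens cannot be told apart in this test. Chloro in place of methylamino gives a 1.6-fold higher number from compound 1 to compound 3 (0.20 log units; within the scatter), which means that all three groups seen at this position, methylamino, fluoro and chloro, now lie within the scatter of one another, a sameness that a single pair could not show. Nothing measured here explains this sameness.

Going by these compounds, whether a carboxylic acid, a nitrile or a longer chain such as butoxy on this same carbon would move the number beyond the scatter remains open. Also open, on these data alone, is whether changes elsewhere on the shared core, such as a hydroxy group in place of the methoxy group, would leave the number just as unmoved.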